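A few compounds are considered here, and "the series" means these few. Any claim that something is new, unique, unknown or untested is made for them only; others in the source may bear on it.

Measured so far in a functional assay on RT-112 cells (Homo sapiens) for antiproliferative activity, read by MTT assay, with a stated time of 72 h; on this read-out lower numbers stand for stronger inhibition of growth and higher numbers for weaker inhibition of growth 
- Compound 1 `COc1cc(Nc2ncnc3c(NC(=O)Nc4ccc(C)c(C)c4)cccc23)cc(OC)c1` gives 8.8 nM 
- Compound 2 `COc1cc(Nc2ncnc3c(NC(=O)Nc4ccccc4Cl)cccc23)cc(OC)c1` gives 356 nM 

Compound 2 has the higher of these two numbers, so it is the weaker growth inhibitor of the pair. Among the measured compounds shown here, the only measured step is a 40-fold higher number from compound 1 to compound 2 (1.61 log units; beyond the scatter) and it comes from putting 2-chlorophenyl in place of 3,4-dimethylphenyl. Compound 3 `COc1cc(Nc2ncnc3c(NC(=O)Nc4cccc(Cl)c4Cl)cccc23)cc(OC)c1` keeps everything in compound 2 except that 2-chlorophenyl becomes 2,3-dichlorophenyl (chloro in place of hydrogen on an aromatic carbon), with chloro in place of hydrogen on an aromatic carbon, ortho to a chloro group. The measured step shows that this part of the molecule can matter greatly, but it replaced a whole group rather than adding one chloro. It therefore bears only loosely on this change. A much smaller change is expected, tilted towards compound 1, and the expected step is a 2.1-fold lower number from compound 2 to compound 3 (0.32 log units; beyond the scatter) in this assay as an estimate only. Compound 3 is estimated at 170 nM (expected range 40 nM to 700 nM).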

Compound 3, concentration for 50% growth inhibition: 63.2 nM
Beside the measured number, compound 3's estimate is 2.7-fold (0.43 log units) above it; the range from low to high includes it.
By their numbers in this assay, from the lowest: compound 1; then compound 3; then compound 2.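

In this assay, adding one chloro to the 2-chlorophenyl group, on the aromatic carbon ortho to the chloro group already there, gives a 5.6-fold lower number from compound 2 to compound 3 (0.75 log units; beyond the scatter) and leaves the rest of the molecule unchanged. A single added atom at this position can therefore shift the number beyond the scatter, which the earlier swap of a whole group could not show. The 2,3-dichlorophenyl group still falls short of the 3,4-dimethylphenyl group, with a 7.2-fold higher number from compound 1 to compound 3 (0.86 log units; beyond the scatter), so the added chloro recovers only part of the loss seen in the earlier step, and nothing measured here explains the change.

Still open, going by these compounds, is whether a methyl group, a methoxy group or an amine entering in place of that hydrogen would give a similar step. Also open, on these data alone, is whether the added chloro would have a similar effect without the chloro group already on the ring.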